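A few compounds are considered here, and "the series" means these few. Any claim that something is new, unique, unknown or untested is made for them only; others in the source may bear on it.

Working notes on a small amide series tested for whole-animal tolerability.

Compound 1 `C=CCNC(=O)/C(C)=C(/C)c1ccccc1` and compound 2 `C=CCNC(=O)/C(C)=C(/C)c1ccc(C)cc1` share one core; compound 3 `C#CCNC(=O)/C(C)=C(\C)c1ccccc1` and the as yet unmeasured compound 4 `C#CCNC(=O)/C(C)=C(\C)c1ccc(C)cc1` share a second core. How the core of compound 3 differs from the core of compound 1 is not broken down here.

In a toxicity assay on the whole organism (strain Icem-CET (SPF Caw)) for cytotoxicity, with Mus musculus as the target (on this read-out higher numbers stand for an effect only at larger amounts of compound and lower numbers for an effect already at smaller amounts), compound 1 gives 400 mg/kg. Compound 2, which carries the change (methyl in place of hydrogen on an aromatic carbon), gives 400 mg/kg in this assay, so the step of no change at the digits printed from compound 1 to compound 2 (within the scatter) is flat. Compound 3 gives 150 mg/kg in this assay, the lowest of the three numbers; its gap to compound 1 and to compound 2 is in each case beyond the usual scatter, so an effect at smaller amounts is seen on the second core than on the first. No finer account of why the two cores part is available from these data.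

The change from compound 3 to compound 4 is methyl in place of hydrogen on an aromatic carbon, the same change as that from compound 1 to compound 2, the place being described in identical words. Going by the values given here, the only precedent for it is the flat step no change at the digits printed from compound 1 to compound 2 (within the scatter), which is the basis for expecting compound 4 to sit close to compound 3. The expected step of no change at the digits printed from compound 3 to compound 4 (within the scatter) is therefore estimated as essentially none. Among the compounds with values here, compound 4 is estimated at 150 mg/kg in this assay, with a range of 75 mg/kg to 320 mg/kg that mostly reflects measurement scatter and the single precedent.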

Compound 4, dose for half-maximal effect: 150 mg/kg
Compound 4: the middle estimate sits on the measured number at the digits printed, and the stated range covers the measured number.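

In this assay, methyl in place of hydrogen on an aromatic carbon, on a six-membered aromatic ring of carbon only and para to a large group, again leaves the read-out flat on the second core, with no change at the digits printed from compound 3 to compound 4 (within the scatter). Set beside the step on the first core, the change carries across the two cores in this series without a detectable difference: the same change on two cores in this assay, no change at the digits printed (within the scatter) from compound 1 to compound 2 and no change at the digits printed (within the scatter) from compound 3 to compound 4, 1.0-fold (0.00 log units) apart, within the scatter of two such steps. This shows only that the flat result holds on these two cores in this one whole-animal read-out; it gives no reason for the flatness and does not establish that the same change would be flat on any further core or in any other read-out.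

Going by these compounds, only hydrogen and methyl appear at this aromatic carbon, so it remains open whether a longer chain such as ethyl, a methoxy group, an amine or a carboxylic acid in the same place would also leave the read-out flat. Also open, on these data alone, is which part of the difference between the core of compound 1 and the core of compound 3 goes with the separation between the two cores.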